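Swapping the amino group of compound 2 for dipropylamino

This account rests on a few compounds, and the source may have more. Where it says the series, first, only, none or still open, it means among the compounds named here.

For the measured compounds named here, in a functional assay on the whole organism for positive allosteric modulation, with Mus musculus as the target (on this read-out lower numbers stand for an effect already at smaller amounts and higher numbers for an effect only at larger amounts of compound), compound 2 (`CCC(=O)N(c1ccc(Cl)c(Cl)c1)C1CCCC1N`) gives 0.02 mg/kg and holds the lower of the two numbers so far. Compound 1 (`CCC(=O)N(c1ccc(C#N)cc1)C1CCCC1N(C)C`) gives 10 mg/kg in the same test. That gap lies beyond the usual scatter, but the two compounds differ in more than one place, so it cannot be tied to a single change. Compound 3 (`CCCN(CCC)C1CCCC1N(C(=O)CC)c1ccc(Cl)c(Cl)c1`) has dipropylamino in place of amino on a saturated ring carbon of compound 2 (dipropylamino in place of amino on a saturated ring carbon). Going by the values given here, no measured pair isolates this change. The only weak hint is that compound 1, which also lacks the plain amino group, stands at 10 mg/kg on the higher side. A rise beyond the scatter is therefore expected in this assay and the estimated move is a 50-fold higher number from compound 2 to compound 3 (1.70 log units; beyond the scatter) toward larger doses. For compound 3 the expected value is 1 mg/kg within an estimated range from 0.1 mg/kg to 10 mg/kg as the likely span.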

Compound 3, dose for half-maximal effect: 2 mg/kg
For compound 3 the middle estimate is 2.0-fold (0.30 log units) below the measured one; measured number inside the range.
By their numbers in this assay, from the lowest: compound 2; then compound 3; then compound 1.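

Until now the gap at this position could not be tied to a single change, but here one change alone, in this assay, gives a 100-fold higher number from compound 2 to compound 3 (2.00 log units; beyond the scatter). The amino group on the saturated ring carbon therefore cannot be replaced by dipropylamino without a large shift toward higher doses, although the rest of compound 2 stays the same. The swap changes the group from 1 heavy atom and 1 hydrogen-bond donor to 7 heavy atoms and 0 hydrogen-bond donors, and no measurement shown gives a cause for the step.

The compounds shown leave open which of these differences matters, since both arrive in the same step. They also leave open how methylamino or diethylamino at this position would read on the core of compound 2.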